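This account rests on a few compounds, and the source may have more. Where it says the series, first, only, none or still open, it means among the compounds named here.

Measured compounds in an assay on membranes from brain for displacement of a labelled ligand from Sigma non-opioid intracellular receptor 1 (Cavia porcellus), read by scintillation counting, with a stated time of 120 min; a lower number here means a stronger inhibitor, a higher number a weaker inhibitor:

compound 1, `N#Cc1ccc(-c2scc3c2CCOC32CCN(Cc3ccccc3)CC2)cc1`: 3.4 nM
compound 2, `COC1Cc2c(csc2-c2ccccc2)C2(CCN(Cc3ccccc3)CC2)O1`: 1 nM
compound 3, `COC1Cc2c(csc2-c2cccc3ccccc23)C2(CCN(Cc3ccccc3)CC2)O1`: 5 nM

Among these three, compound 3 has the highest number in this assay. Compound 1 stands nearest to it, within the scatter of repeated measurement, while compound 2 stands furthest, beyond the scatter. The next compound, compound 4, `COC1Cc2c(csc2-c2ccc(C#N)cc2)C2(CCN(Cc3ccccc3)CC2)O1`, differs from compound 3 in one place: 4-cyanophenyl in place of naphthalen-1-yl on an aromatic carbon.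

Going by the values given here, one measured step bears on this position on the thiophene-type ring of the shared core: a 5.0-fold higher number from compound 2 to compound 3 (0.70 log units; beyond the scatter). This shows that exchange of the aryl group at this place moves the number by a modest amount, and that the naphthalen-1-yl group carries the higher number. Compound 1 bears the 4-cyanophenyl group on a core lacking the methoxy group; in this assay compound 1 gives 3.4 nM, a number close to that of compound 3. Compound 4 combines the 4-cyanophenyl group of compound 1 with the methoxy-bearing core of compound 2, whose number is the lowest of the three.

The expected step is therefore a lower number, of modest size: a 2.0-fold lower number from compound 3 to compound 4 (0.30 log units; within the scatter). Compound 4 is estimated at 2.5 nM, within a range from 0.8 nM to 8 nM.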

Compound 4, inhibition constant: 0.25 nM
Compound 4: the middle estimate sits 10-fold (1.00 log units) above what was measured, and the stated range ends above it.
By their numbers in this assay, from the lowest: compound 4; then compound 2; then compounds 1 and 3 (each within the scatter of the next).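

In this assay, the change from naphthalen-1-yl to 4-cyanophenyl gives a 20-fold lower number from compound 3 to compound 4 (1.30 log units; beyond the scatter) and so is a large step, which shows that the aryl group next to the ring sulfur can move the number further than the modest step of a 5.0-fold higher number from compound 2 to compound 3 (0.70 log units; beyond the scatter) had suggested. Cyano in place of hydrogen on the phenyl group gives a 4.0-fold lower number from compound 2 to compound 4 (0.60 log units; beyond the scatter) on the same methoxy-bearing core, so that, among the three aryl groups on this core, the lowest number belongs to 4-cyanophenyl and the highest to naphthalen-1-yl, with phenyl lying between them. With 4-cyanophenyl held fixed, methoxy in place of hydrogen on a saturated ring carbon gives a 14-fold lower number from compound 1 to compound 4 (1.13 log units; beyond the scatter) as a large step, which the closeness of compound 1 and compound 3, two compounds differing in more than one place, could not reveal.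

Going by these compounds, it remains open whether a carboxylic acid, an amine or a chlorine atom in place of the cyano group would give a similar number, and whether cyano and methoxy act independently, as that would need phenyl on the core of compound 1. No evidence given here accounts for any of these steps.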